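Dimethylphenyl analogue in a series held at the assay limit

This account rests on a few compounds, and the source may have more. Where it says the series, first, only, none or still open, it means among the compounds named here.

Compound 1 `Cc1ccccc1-n1nncc1CN1C(=O)C2(C(C#N)=C(N)Oc3c2c2nc4ccccc4nc2c2ccccc32)c2ccccc21` bears 2-methylphenyl on an aromatic nitrogen of the shared core. In a functional assay on HepG2 cells (Homo sapiens) for antiproliferative activity, read by MTT assay, with a stated time of 48 h (a higher number here means a weaker inhibitor, a lower number a stronger inhibitor), compound 1 gives > 50000 nM, which is a limit of the assay and not a number. Compound 2 `COc1ccc(-n2nncc2CN2C(=O)C3(C(C#N)=C(N)Oc4c3c3nc5ccccc5nc3c3ccccc43)c3ccccc32)cc1` bears 4-methoxyphenyl at the same nitrogen. In this assay compound 2 gives > 50000 nM, again a limit. Compound 3 `CC(=O)Nc1ccc(-n2nncc2CN2C(=O)C3(C(C#N)=C(N)Oc4c3c3nc5ccccc5nc3c3ccccc43)c3ccccc32)cc1` bears 4-acetamidophenyl. In this assay compound 3 gives > 50000 nM, also a limit. Compound 3 therefore stands where both companions stand, since all three rest at the limit of > 50000 nM in this assay, at which 3 of the 3 values shown sit. The steps a step that the two limits leave unreadable from compound 1 to compound 2, a step that the two limits leave unreadable from compound 1 to compound 3 and a step that the two limits leave unreadable from compound 2 to compound 3 cannot be read in size or direction.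

The unmeasured compound 4 `Cc1ccc(C)c(-n2nncc2CN2C(=O)C3(C(C#N)=C(N)Oc4c3c3nc5ccccc5nc3c3ccccc43)c3ccccc32)c1` differs from compound 3 by 2,5-dimethylphenyl in place of 4-acetamidophenyl on an aromatic nitrogen. Going by the values given here, no measured step that bears on this change has a readable size, so nothing indicates that exchanging the aryl group moves the read-out off the limit. The step is expected to be a step that the limit leaves unreadable from compound 3 to compound 4, within the scatter. Compound 4 is expected to give 60000 nM in this assay, with a range from 20000 nM to 200000 nM, and most likely to be reported as a limit once more.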

Compound 4, half-maximal inhibitory concentration: > 50000 nM
Compound 4 gave a limit, no number; the forecaster's own chance of this, stated with the estimate: 80%; the middle value does not contradict the limit.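

In this assay compound 4 gives > 50000 nM, which is a limit of the assay and not a number, so its steps from compound 1, compound 2 and compound 3 cannot be read in size or direction. Whether any aryl group on this nitrogen of the shared core can move the read-out off the limit stays open, as all the compounds shown rest at one value: the limit of > 50000 nM in this assay, at which 4 of the 4 values shown sit.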